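A 3,5-dimethylphenyl to 3-chlorophenyl swap on a sulfur

A few compounds are considered here, and "the series" means these few. Any claim that something is new, unique, unknown or untested is made for them only; others in the source may bear on it.

In an ADME assay on cells (Homo sapiens) for cytotoxicity, read by resazurin assay, with a stated time of 5 days (on this read-out higher numbers stand for lower toxicity in this test and lower numbers for higher toxicity in this test), compound 1 (`COc1ccc(-c2nc(CSc3cccc(Cl)c3Cl)nc3ccsc23)cn1`) gives > 50000 nM, which is a limit of the assay. Compound 2 (`COc1ccc(-c2nc(CNc3cccc(Cl)c3)nc3ccsc23)cn1`) gives > 50000 nM, again a limit. Compound 3 (`COc1ccc(-c2nc(CSc3cc(C)cc(C)c3)nc3ccsc23)cn1`) gives > 50000 nM, also a limit and not a number. Compound 3 therefore stands with the other two at the limit of > 50000 nM in this assay, at which 3 of the 3 values shown sit.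

Compound 4 (`COc1ccc(-c2nc(CSc3cccc(Cl)c3)nc3ccsc23)cn1`) carries 3-chlorophenyl in place of 3,5-dimethylphenyl on a sulfur. Two measured changes bear on this: a step that the two limits leave unreadable from compound 1 to compound 3, and a step that the two limits leave unreadable from compound 2 to compound 3. Neither has a readable size, so no measured size can be carried over. With compound 1, compound 2 and compound 3 all at the limit of > 50000 nM in this assay, at which 3 of the 3 values shown sit, no change beyond the scatter is expected in this assay, and a further limit is the likeliest report. The expected change is a number no higher from compound 3 to compound 4 (the limit leaves the size open). For compound 4 the estimate is 50000 nM, with an expected range from 25000 nM to 100000 nM.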

Compound 4, half-maximal cytotoxic concentration: > 10000 nM
Compound 4: no number, only a limit (the forecaster's own chance of this, stated with the estimate: 85%); the middle value does not contradict the limit.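

Compound 4 gives only a limit in this assay, as do compound 1, compound 2 and compound 3, so no step among these four compounds can be read. The compounds shown leave open at what concentration, if any, each becomes cytotoxic.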